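The source may report more compounds than this note shows. Statements on the series, on what has been measured and on what is new or still open speak of the compounds shown alone.

Measured compounds:
- compound 1, `COc1cc(C2=NN(C(C)=O)C(c3ccccc3C(F)(F)F)O2)cc(OC)c1OC`: 34.8%
- compound 2, `COc1cc(C2=NN(C(C)=O)C(c3cc(OC)c(OC)c(OC)c3)O2)cc(OC)c1OC`: -1.4%

Of the compounds shown here, two sharing one core have been tested in a functional assay on BGC-823 cells (Homo sapiens) for antiproliferative activity, read by MTT assay, tested at 5 uM; a higher number here means a stronger effect of the compound at the concentration tested, a lower number a weaker effect. Compound 1, carrying 2-(trifluoromethyl)phenyl, gives 34.8%, the higher of the two numbers. Compound 2, with a trimethoxyphenyl group at the same saturated ring carbon, gives -1.4%, and the gap between compound 1 and compound 2 lies beyond the usual scatter of this assay.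

Compound 3, `COc1cc(C2=NN(C(C)=O)C(c3ccc(C(F)(F)F)cc3)O2)cc(OC)c1OC`, has not yet been measured. It differs from compound 1 in a single place: 4-(trifluoromethyl)phenyl in place of 2-(trifluoromethyl)phenyl on a saturated ring carbon. The two have the same atoms, joined differently. Going by the values given here, nothing measured so far tells how such a change acts in this assay, so the step from compound 1 is expected to be small, in either direction, and within the scatter, meaning a number 4.8 percentage points lower from compound 1 to compound 3 (within the scatter). Compound 3 is thus estimated at 30%, with a range from 5% to 55%.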

Compound 3, a percentage reported as inhibition, at one concentration (the size of the read-out at that concentration, not a potency): 3.4%
Compound 3: middle estimate off by 26.6 percentage points, on the high side, and the stated range ends above it.
By their numbers in this assay, from the lowest: compounds 2 and 3 (each within the scatter of the next); then compound 1.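

In this assay, 4-(trifluoromethyl)phenyl in place of 2-(trifluoromethyl)phenyl gives a large change, a number 31.4 percentage points lower from compound 1 to compound 3 (beyond the scatter), although the two groups hold the same atoms. At this saturated ring carbon, then, the read-out depends not only on which atoms the group carries but also on how they are joined, and the number for compound 1 does not carry over to its rearranged partner. Nothing available here explains this step.

The compounds shown leave open whether the trifluoromethyl group itself is needed in 2-(trifluoromethyl)phenyl, or whether a chlorine atom or a methoxy group in its place would give a similar number. They also leave open how compound 1 would respond if its acetyl group were replaced by a longer chain, such as propanoyl.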